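A few compounds are considered here, and "the series" means these few. Any claim that something is new, unique, unknown or untested is made for them only; others in the source may bear on it.

Compound 1 `O=[N+]([O-])c1cccc(-c2nn(-c3ccccc3)cc2C(Nc2nc3ccccc3s2)c2c(O)ccc3ccccc23)c1` gives 8220 nM
Compound 2 `COc1ccc2nc(NC(c3cn(-c4ccccc4)nc3-c3cccc([N+](=O)[O-])c3)c3c(O)ccc4ccccc34)sc2c1` gives 6140 nM
Compound 3 `Oc1ccc2ccccc2c1C(Nc1nc2ccc(Cl)cc2s1)c1cn(-c2ccccc2)nc1-c1ccc(F)cc1` gives 30100 nM

In a functional assay on HeLa cells (Homo sapiens) for antiproliferative activity, read by MTT assay, with a stated time of 48 h (a higher number here means a weaker inhibitor, a lower number a stronger inhibitor), compound 3 has the highest number of the three, which makes it the weakest inhibitor measured so far. Compound 4 `O=[N+]([O-])c1cccc(-c2nn(-c3ccccc3)cc2C(Nc2nc3ccc(Cl)cc3s2)c2c(O)ccc3ccccc23)c1` differs from compound 3 in a single group (3-nitrophenyl in place of 4-fluorophenyl on an aromatic carbon), with 3-nitrophenyl in place of 4-fluorophenyl on an aromatic carbon of a five-membered aromatic ring with 2 nitrogen.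

Among the compounds with values here, no measured step covers this exchange. The only one available, a 1.3-fold lower number from compound 1 to compound 2 (0.13 log units; within the scatter), is a methoxy in place of hydrogen at another place, so it says nothing directly about this group. It does show that the two compounds carrying 3-nitrophenyl sit close together. Both lie well under compound 3, with compound 1 at 8220 nM and compound 2 at 6140 nM. A step to a lower number in this assay, beyond the scatter, is therefore expected, though with wide uncertainty.

The estimated change is a 3.3-fold lower number from compound 3 to compound 4 (0.52 log units; beyond the scatter). For compound 4 the expected value is 9000 nM, with an estimated range from 3500 nM to 22000 nM.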

Compound 4, half-maximal inhibitory concentration: 15500 nM
Compound 4: the middle estimate sits 1.7-fold (0.24 log units) below what was measured, and the stated range covers the measured number.
By their numbers in this assay, from the lowest: compounds 2, 1, 4 and 3 (each within the scatter of the next, the first and the last beyond it).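

In this assay the exchange of 4-fluorophenyl for 3-nitrophenyl on this aromatic carbon, read directly with the chloro group held fixed, gives a 1.9-fold lower number from compound 3 to compound 4 (0.29 log units; within the scatter) and so does not separate the two groups. With 3-nitrophenyl held fixed, chloro in place of hydrogen elsewhere on the core also stays within the scatter (a 1.9-fold higher number from compound 1 to compound 4 (0.28 log units; within the scatter)), whereas chloro in place of methoxy gives a modest step beyond it (a 2.5-fold higher number from compound 2 to compound 4 (0.40 log units; beyond the scatter)). No measurement available here bears on the reason for these steps.

Within the data shown here, only two aryl groups appear at this position, so it remains open how a plain phenyl, or a phenyl carrying an amine or a carboxylic acid, would read. From the compounds shown here alone, it is also open whether the exchange would read the same with hydrogen or methoxy in place of the chloro group.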